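Pyrrol-2-yl ketone at the carbonyl carbon: an expectation

The source may report more compounds than this note shows. Statements on the series, on what has been measured and on what is new or still open speak of the compounds shown alone.

Compound 1, `COc1ccc(-c2cc3ccccc3nc2C=O)cc1`: in a functional assay on H184B5F5/M10 cells (Homo sapiens) for antiproliferative activity, read by XTT assay, with a stated time of 72 h (on this read-out lower numbers stand for stronger inhibition and higher numbers for weaker inhibition), compound 1 gives > 10000 nM, which is a limit of the assay and not a number.
Compound 2, `COc1ccc(-c2cc3ccccc3nc2/C=C/C(=O)c2ccc(OC)cc2OC)cc1`: in this assay compound 2 gives 6110 nM.
Compound 3, `COc1ccc(-c2cc3ccccc3nc2/C=C/C(=O)c2cccs2)cc1`: in this assay compound 3 gives 7030 nM.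

Of the two numbers, compound 2 holds the lower one, but the step of a 1.2-fold higher number from compound 2 to compound 3 (0.06 log units; within the scatter) lies within the scatter, so the two are not ordered. Compound 4, `COc1ccc(-c2cc3ccccc3nc2/C=C/C(=O)c2ccc[nH]2)cc1`, differs from compound 2 at the carbonyl carbon: 1H-pyrrol-2-yl in place of 2,4-dimethoxyphenyl on a carbonyl carbon. Within the data shown here, the one measured step that resembles this change is the one just given, where another five-membered aromatic ring took the place of 2,4-dimethoxyphenyl on the carbonyl carbon, and it stayed within the scatter. No step beyond the scatter is therefore expected in this assay, in either direction. Compound 4 is accordingly estimated at 6500 nM, within 3000 nM to 13000 nM, an expected step of a 1.1-fold higher number from compound 2 to compound 4 (0.03 log units; within the scatter).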

Compound 4, half-maximal inhibitory concentration: > 10000 nM
Compound 4: no number, only a limit (the forecaster's own chance of this, stated with the estimate: 25%); middle value at least 1.5-fold (0.18 log units) away from the limit.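

With 1H-pyrrol-2-yl on the carbonyl carbon, compound 4 gives only a limit of the assay in this assay, not a number, which is new for a five-membered aromatic ring at this place: the limit of > 10000 nM in this assay, at which 2 of the 4 values shown sit.
The change gives an at least 1.6-fold higher number from compound 2 to compound 4 (0.21 log units; that floor lies within the scatter), and an at least 1.4-fold higher number from compound 3 to compound 4 (0.15 log units; that floor lies within the scatter), so no loss is established. The step from compound 1 to compound 4 cannot be read.

Still open, as far as these compounds go, is how far compound 4 lies past its limit. Also open, from the compounds shown here alone, is whether furan-2-yl or an N-methylpyrrol-2-yl ring on the carbonyl carbon would give a number in this assay.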